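The source may hold more compounds than are shown below. What is called first, only, known or untested is meant among the compounds shown, and "the series" means these compounds.

Of the compounds shown here, three have been measured in a physicochemical assay for acid dissociation. Compound 1 `COc1cccc(CNCCCNc2ccnc3cc(Cc4ccc(F)cc4)ccc23)c1O` gives 9.47. Compound 2 `COc1cccc(CNCCCNc2ccnc3cc(Oc4cccc(N(C)C)c4)ccc23)c1O` gives 9.28; the only difference between the two is a number 0.19 log units lower from compound 1 to compound 2 (within the scatter), and that change sits on the far end of the shared core, away from the amine. Compound 3 `c1coc(CNCCCNc2ccnc3cc(-c4cccc5ccccc45)ccc23)c1` gives 9.47, the same figure as compound 1, and compound 2 lies within the scatter of both.

Compound 4 `COc1cccc(CNCCCNc2ccnc3cc(-c4cccc5ccccc45)ccc23)c1O` has not been measured. It differs from compound 3 in one place: 2-hydroxy-3-methoxyphenyl in place of furan-2-yl on a saturated chain carbon bound to an amine nitrogen. No measured step touches this part of the molecule, so nothing shown speaks directly to it. What the numbers do show is that compounds 1 and 2, which already carry the 2-hydroxy-3-methoxybenzyl group, and compound 3, with its (furan-2-yl)methyl group, all sit together in this assay.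

On that basis the step of a number 0.02 log units lower from compound 3 to compound 4 (within the scatter) is expected to stay within the scatter. For compound 4 the value in this assay is estimated at 9.45, between 9.1 and 9.8.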

Compound 4, acid dissociation constant: 9.47
Estimate against measurement, compound 4: 0.02 log units below; measured number inside the range.
By their numbers in this assay, from the lowest: compounds 2, 1, 3 and 4 (each within the scatter of the next).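

In this assay, the group on a saturated chain carbon bound to an amine nitrogen can now be compared directly: 2-hydroxy-3-methoxyphenyl in place of furan-2-yl gives no change at the digits printed from compound 3 to compound 4 (within the scatter), although the entering group carries a hydrogen-bond donor and the leaving group carries none. With that group held fixed, naphthalen-1-yl on an aromatic carbon gives a number 0.19 log units higher from compound 2 to compound 4 (within the scatter) in place of 3-(dimethylamino)phenoxy, and no change at the digits printed from compound 1 to compound 4 (within the scatter) in place of 4-fluorobenzyl. Neither place has moved the number beyond the scatter in these four compounds, and no supporting evidence bears on this result.

From the compounds shown here alone, whether a carboxylic acid or a second amine in place of these groups, or a longer chain joining them to the shared core, would shift the value in this assay stays open. These numbers also do not tell which atom gives up the proton.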